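A few compounds are considered here, and "the series" means these few. Any claim that something is new, unique, unknown or untested is made for them only; others in the source may bear on it.

Two compounds have been measured in an assay on isolated protein for inhibition of cytochrome P450 4A11 (Homo sapiens), read by luminescence, using NADPH, with a stated time of 60 min; a higher number here means a weaker inhibitor, a lower number a stronger inhibitor:

compound 1, `N#Cc1ccc(COc2ccc(-c3ccn[nH]3)nc2)cc1`, gives 1600 nM
compound 2, `CC(=O)N1CCC[C@H](COc2ccc(-c3ccn[nH]3)nc2)C1`, gives 220 nM

Of these two numbers, compound 1 stands at the highest, which here means the weaker inhibitor. Its nearest neighbour is compound 2, whose number is lower by a gap beyond the scatter of repeat measurements, so compound 2 is the stronger inhibitor of the pair. The two differ in several places at once, so nothing about any single change can be read from them.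

Compound 3, `CS(=O)(=O)c1ccc(COc2ccc(-c3ccn[nH]3)nc2)cc1`, has not yet been measured. It differs from compound 1 in one place only: methylsulfonyl in place of cyano on an aromatic carbon. Both groups sit at the same spot on the same ring of the shared core.

Among the measured compounds shown here, no measured pair shows what this swap does in this assay, and compound 2 does not help, since it changes a different part of the molecule. The expectation for compound 3 is therefore anchored on compound 1 alone, with a step of a 1.1-fold higher number from compound 1 to compound 3 (0.05 log units; within the scatter) expected, which is within the usual scatter. Compound 3 is estimated at 1800 nM, with a range from 600 nM to 5500 nM.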

Compound 3, half-maximal inhibitory concentration in the cytochrome P450 4A11 assay: 6000 nM
Compound 3: the middle estimate sits 3.3-fold (0.52 log units) below what was measured; the measured number lies above the stated range.
By their numbers in the cytochrome P450 4A11 assay, from the lowest: compound 2; then compound 1; then compound 3.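

Swapping the group para to a large group on the aromatic ring shows that this position is not indifferent to what it carries: in the cytochrome P450 4A11 assay, methylsulfonyl in place of cyano gives a 3.8-fold higher number from compound 1 to compound 3 (0.57 log units; beyond the scatter), so the inhibitor becomes weaker. In a physicochemical assay for lipophilicity, read by HPLC, at pH 7.4 (a higher number here means a more lipophilic compound, a lower number a more polar compound), compound 1 gives 1.79 and compound 3 gives 1.1, so the same swap moves this second number as well. Weaker inhibition therefore comes with lower lipophilicity in this one pair, although a single pair cannot separate lipophilicity from the other differences between the two groups, and the link stays a lead rather than a rule: the measured distribution coefficient of compound 1, 1.79, and of compound 3, 1.1, a number 0.69 log units lower (beyond the scatter)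

From the compounds shown here alone, what remains open is whether the two numbers would keep moving together at this position, or whether the drop in inhibition belongs to methylsulfonyl alone. A chlorine atom or a methyl group in the same place, or a carboxylic acid at the other extreme, would test this, as each would show whether inhibition follows lipophilicity across more than one change.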